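The source may report more compounds than this note shows. Statements on the series, on what has been measured and on what is new or still open speak of the compounds shown alone.

Compound 1 `COc1cc(N(C)CCN(C)C)c(NC(=O)/C=C\C(C)C)cc1Nc1nccc(-c2cn(C)c3ccccc23)n1`: 4390 nM
Compound 2 `C=CC(=O)Nc1cc(Nc2nccc(-c3cn(C)c4ccc(F)cc34)n2)c(OC)cc1N(C)CCN(C)C`: 429 nM
Compound 3 `CC/C=C\C(=O)Nc1cc(Nc2nccc(-c3cn(C)c4ccc(F)cc34)n2)c(OC)cc1N(C)CCN(C)C`: 5290 nM

In a functional assay on HepG2 cells (Homo sapiens) for antiproliferative activity, read by MTT assay, with a stated time of 72 h (a higher number here means a weaker inhibitor, a lower number a stronger inhibitor), compound 3 gives the highest of the three numbers; compound 1 sits within the scatter of it, while compound 2 lies well apart, the step of a 12-fold higher number from compound 2 to compound 3 (1.09 log units; beyond the scatter) being the only one beyond the scatter. Compound 4 `COc1cc(N(C)CCN(C)C)c(NC(=O)/C=C\C(C)C)cc1Nc1nccc(-c2cn(C)c3ccc(F)cc23)n1` differs from compound 3 by methyl in place of hydrogen on a saturated chain carbon bound to a double-bonded chain carbon and a saturated chain carbon; that is, but-1-en-1-yl becomes 3-methylbut-1-en-1-yl on the carbonyl. Within the data shown here, no measured step isolates this change. Compound 1 carries the same 3-methylbut-1-en-1-yl group and gives 4390 nM, close to compound 3, which suggests the branching itself matters little here. Compound 4 is therefore expected to give about 4500 nM (range 1500 nM to 13000 nM), a step of a 1.2-fold lower number from compound 3 to compound 4 (0.07 log units; within the scatter) that is estimated to stay within the scatter.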

Compound 4, half-maximal inhibitory concentration: 3920 nM
Estimate against measurement, compound 4: 1.1-fold (0.06 log units) above; low and high end bracket the measured number.
By their numbers in this assay, from the lowest: compound 2; then compounds 4, 1 and 3 (each within the scatter of the next).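

In this assay the methyl that turns but-1-en-1-yl into 3-methylbut-1-en-1-yl leaves the number within the scatter (a 1.3-fold lower number from compound 3 to compound 4 (0.13 log units; within the scatter)), so branching at this saturated chain carbon shows no measurable effect. The fluoro on the aromatic carbon also stays within the scatter (a 1.1-fold lower number from compound 1 to compound 4 (0.05 log units; within the scatter)), while the vinyl compound stands apart from the branched chain (a 9.1-fold higher number from compound 2 to compound 4 (0.96 log units; beyond the scatter)) as it does from the unbranched one. Nothing measured here bears on these differences. Still open, on these data alone, is whether a shorter prop-1-en-1-yl group, or a chain ending in a dimethylamine, would bring the number closer to that of compound 2.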